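The source may report more compounds than this note shows. Statements on the series, on what has been measured and on what is new or still open speak of the compounds shown alone.

Compound 1 `CC1(C)[C@H]2CC[C@]1(C)N(Cc1cn(-c3ccc(C#N)cc3)nn1)C(=O)C2` gives 380 nM in a functional assay on OVCAR-3 cells (Homo sapiens) for inhibition, read by MTT assay, with a stated time of 24 h (a lower number here means a stronger inhibitor, a higher number a weaker inhibitor), the higher of the two numbers measured; the nearest is compound 2 `CC1(C)[C@H]2CC[C@]1(C)N(Cc1cn(-c3cccc(Br)c3)nn1)C(=O)C2`, which gives 30 nM. Going by the values given here, the only step measured so far, a 13-fold lower number from compound 1 to compound 2 (1.10 log units; beyond the scatter), swaps both the group and its position on the ring. Compound 3 `COc1ccc(-n2cc(CN3C(=O)C[C@@H]4CC[C@@]3(C)C4(C)C)nn2)cc1` keeps the position and changes only the group: methoxy in place of cyano on an aromatic carbon. That step bears on it loosely, since the cyano left there too, so a modest drop toward a stronger number is expected for compound 3 in this assay, roughly a 1.9-fold lower number from compound 1 to compound 3 (0.28 log units; within the scatter), giving an estimate of 200 nM within 60 nM to 800 nM.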

Compound 3, half-maximal inhibitory concentration: 250 nM
Compound 3: middle estimate off by 1.3-fold (0.10 log units), on the low side, within the range that was stated.
By their numbers in this assay, from the lowest: compound 2; then compounds 3 and 1 (each within the scatter of the next).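

In this assay, methoxy in place of cyano on an aromatic carbon para to a large group gives a 1.5-fold lower number from compound 1 to compound 3 (0.18 log units; within the scatter) and so does not separate the two groups at this position. The move to 4-methoxyphenyl leaves 3-bromophenyl clearly ahead, read in reverse from an 8.3-fold higher number from compound 2 to compound 3 (0.92 log units; beyond the scatter) here, so compound 2 now stands apart from both para-substituted compounds. No measurement here gives a reason for either step. Still open, from the compounds shown here alone, is whether the bromine or its ring position matters more, and how an amine or a carboxylic acid would fare on this ring.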